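Removing 2-ethoxyethyl from compound 2

A few compounds are considered here, and "the series" means these few. Any claim that something is new, unique, unknown or untested is made for them only; others in the source may bear on it.

Compound 1 (`CCOCCOC(=O)C(=O)Nc1nc(-c2cc(Br)no2)cs1`), compound 2 (`CCOCCOC(=O)C(=O)Nc1nc(-c2cc(OC)no2)cs1`) and compound 3 (`CCOCCOC(=O)C(=O)Nc1nc(-c2cc(C(=O)OCC)no2)cs1`) carry the same 2-ethoxyethyl group and differ at one aromatic carbon. In a functional assay on the whole organism with Rattus norvegicus as the target (a higher number here means that more compound is needed for the effect, a lower number that less compound is needed), compound 1 gives > 30 mg/kg as a limit of the assay and not as a number. Compound 2 gives 11 mg/kg as the higher of the two actual numbers, and compound 3 gives 1.9 mg/kg as the lower one. The three measured steps (an at least 2.7-fold lower number from compound 1 to compound 2 (0.43 log units; beyond the scatter); an at least 15-fold lower number from compound 1 to compound 3 (1.19 log units; beyond the scatter); a 5.8-fold lower number from compound 2 to compound 3 (0.76 log units; beyond the scatter)) all lie at that aromatic carbon.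

Compound 4 (`COc1cc(-c2csc(NC(=O)C(=O)O)n2)on1`) keeps the methoxy of compound 2 but changes elsewhere (hydrogen in place of 2-ethoxyethyl on an oxygen next to a carbonyl group), with hydrogen in place of 2-ethoxyethyl on an oxygen next to a carbonyl group. For the measured compounds named here, no measured step touches this place, so none gives a direction for it. Going by the values given here, the step between the two actual numbers (a 5.8-fold lower number from compound 2 to compound 3 (0.76 log units; beyond the scatter)) shows only that a single change can move the read-out beyond the scatter. No clear direction is therefore expected, and the expected step (a 1.2-fold lower number from compound 2 to compound 4 (0.09 log units; within the scatter)) stays within the scatter, with wide uncertainty either way. For compound 4 the estimated value is 9 mg/kg (expected range 1.5 mg/kg to 40 mg/kg).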

Compound 4, dose for half-maximal effect: 8 mg/kg
Compound 4: middle estimate off by 1.1-fold (0.05 log units), on the high side; the range from low to high includes it.
By their numbers in this assay, from the lowest: compound 3; then compounds 4 and 2 (each within the scatter of the next). At a limit, above all of these: compound 1.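

For the compounds shown here, replacing 2-ethoxyethyl with hydrogen on an oxygen next to a carbonyl group, a change that reads 2-ethoxyethoxy to hydroxy, gives in this assay the first measured step at this place: a 1.4-fold lower number from compound 2 to compound 4 (0.14 log units; within the scatter). Compound 2 and compound 4 therefore cannot be told apart in this read-out, even though the whole 2-ethoxyethyl chain is gone, whereas the steps at the aromatic carbon among compound 1, compound 2 and compound 3 all lie beyond the scatter; on this single pair, the read-out is insensitive to this change, at least with methoxy on the aromatic carbon. The information at hand offers no explanation for this outcome.

On these data alone, only the methoxy pair carries this change, and it remains open whether hydroxy in place of 2-ethoxyethoxy would also leave the read-out within the scatter with the ethoxycarbonyl of compound 3 or the bromo of compound 1. As far as these compounds go, it also remains open how a methyl or ethyl group, a longer chain or an amine-bearing chain on this oxygen would compare with 2-ethoxyethyl and hydrogen.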